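From pyrrolidin-1-yl to piperidin-1-yl on the side chain

The source may report more compounds than this note shows. Statements on the series, on what has been measured and on what is new or still open speak of the compounds shown alone.

Three compounds on a shared core have numbers in a toxicity assay on L02 cells (Homo sapiens) for cytotoxicity, read by MTT assay, with a stated time of 72 h; a higher number here means a weaker inhibitor, a lower number a stronger inhibitor. Compound 1 `CN(C)CCCCCn1c2c(c3ccccc31)C(=O)c1c[n+]([O-])c3ccccc3c1C2=O` gives 240 nM, compound 2 `O=C1c2c[n+]([O-])c3ccccc3c2C(=O)c2c1c1ccccc1n2CCN1CCCC1` gives 930 nM and compound 3 `CC1(C)OC[C@@H](Cn2cc(Cn3c4c(c5ccccc53)C(=O)c3c[n+]([O-])c5ccccc5c3C4=O)nn2)O1` gives 2900 nM. Compound 2 therefore holds the middle place, the second highest of the three numbers, and its gaps to both other compounds lie beyond the scatter.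

Compound 4 `O=C1c2c[n+]([O-])c3ccccc3c2C(=O)c2c1c1ccccc1n2CCN1CCCCC1` has not yet been measured. It keeps the core of compound 2 and carries piperidin-1-yl in place of pyrrolidin-1-yl on a saturated chain carbon, two bonds along the chain from an aromatic nitrogen.

For the measured compounds named here, only one measured step involves this place: a 3.9-fold higher number from compound 1 to compound 2 (0.59 log units; beyond the scatter). That modest step, beyond the scatter, exchanged 3-(dimethylamino)propyl for pyrrolidin-1-yl, an open chain for a ring. Going by the values given here, no measured step exchanges one non-aromatic ring for another, so the size of this change in this assay has no direct precedent. A ring-for-ring exchange is expected to move the number less than the step to compound 2 did, and no direction is favoured. The expected step is a 1.0-fold lower number from compound 2 to compound 4 (0.01 log units; within the scatter), within the scatter. Compound 4 is expected at 900 nM, with an estimated range of 350 nM to 2300 nM.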

Compound 4, half-maximal inhibitory concentration: 1050 nM
Compound 4: the middle estimate sits 1.2-fold (0.07 log units) below what was measured, and the stated range covers the measured number.
By their numbers in this assay, from the lowest: compound 1; then compounds 2 and 4 (each within the scatter of the next); then compound 3.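

In this assay, for the compounds shown here, the ring-for-ring exchange at this position, on a saturated chain carbon, two bonds along the chain from an aromatic nitrogen, gives a 1.1-fold higher number from compound 2 to compound 4 (0.05 log units; within the scatter) and thus supplies the first direct reading for a change of ring size here: a five-membered non-aromatic ring and a six-membered one cannot be told apart in this assay. Going by these compounds alone, the exchange of 3-(dimethylamino)propyl for piperidin-1-yl gives a 4.4-fold higher number from compound 1 to compound 4 (0.64 log units; beyond the scatter) and, read with a 3.9-fold higher number from compound 1 to compound 2 (0.59 log units; beyond the scatter), shows that among compounds 1, 2 and 4 the open chain stands apart from both rings, with no compound in this set going against that. Nothing beyond these cytotoxicity numbers bears on the result, so it remains a description without an explanation.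

Open, on these data alone, is whether this insensitivity extends to a ring holding a second hetero atom, such as morpholin-4-yl or 4-methylpiperazin-1-yl, or to a larger ring such as azepan-1-yl. Also open, as far as these compounds go, is whether the gap between the open chain and the rings persists with a longer chain carrying the piperidin-1-yl group, such as 3-(piperidin-1-yl)propyl in place of 2-(piperidin-1-yl)ethyl.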